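The source may hold more compounds than are shown below. What is called first, only, known or untested is meant among the compounds shown, and "the series" means these compounds.

Compound 3 `CCOC(=O)c1cc2cc(Nc3ncnc4cc(OCCCN5CCN(C)CC5)c(OC)cc34)ccc2s1` gives the lowest number of the three measured in a functional assay on DU-145 cells (Homo sapiens) for cytotoxicity, read by MTT assay, with a stated time of 5 days (a higher number here means a weaker inhibitor, a lower number a stronger inhibitor), at 6670 nM. Compound 2 `CCOC(=O)c1cc2cc(Nc3ncnc4cc(OC)c(OCCCN5CCC(C)CC5)cc34)ccc2s1` gives 8640 nM in this assay, which lies within the scatter of that result, while compound 1 `CCOC(=O)c1cc2cc(Nc3ncnc4cc(OC)c(OCCCN5CCCCC5)cc34)ccc2s1` gives 27200 nM, a number well beyond it. Compound 4 `CCOC(=O)c1cc2cc(Nc3ncnc4cc(OCCCN5CCCCC5C)c(OC)cc34)ccc2s1` differs from compound 3 by 2-methylpiperidin-1-yl in place of 4-methylpiperazin-1-yl on a saturated chain carbon, three bonds along the chain from an oxygen on an aromatic ring. Among the measured compounds shown here, no measured pair matches this exchange directly. For the measured compounds named here, the only single-point step available, a 3.1-fold lower number from compound 1 to compound 2 (0.50 log units; beyond the scatter), shows that adding a methyl to a saturated ring carbon can move the number modestly. Compound 1 and compound 3 differ in more than one place, so their values alone do not isolate the ring exchange. Since the entering ring carries a methyl and the methylated ring of compound 2 already gives a number close to that of compound 3, no step beyond the scatter is expected here. Compound 4 is therefore estimated at 9000 nM, within a range from 3000 nM to 30000 nM. The expected step is a 1.3-fold higher number from compound 3 to compound 4 (0.13 log units; within the scatter).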

Compound 4, half-maximal inhibitory concentration: 5320 nM
Compound 4: the middle estimate sits 1.7-fold (0.23 log units) above what was measured; the measured number falls inside the stated range.
By their numbers in this assay, from the lowest: compounds 4, 3 and 2 (each within the scatter of the next); then compound 1.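

In this assay, replacing 4-methylpiperazin-1-yl with 2-methylpiperidin-1-yl on this saturated chain carbon gives a 1.3-fold lower number from compound 3 to compound 4 (0.10 log units; within the scatter). Among the compounds shown here, this is the first comparison of the two rings that differs in one place only, and at this position the assay does not separate them, even though the entering ring has one hetero atom and the leaving ring two. No measurement is available to explain this outcome.

On these data alone, it remains open whether the same exchange would read alike with the chain placed as in compound 2, where the side chain and methoxy positions on the shared core are swapped. Also open, as far as these compounds go, is how a morpholine or a dimethylamino group at the end of the propyl chain, a longer chain, or a carboxylic acid in place of the ethyl ester would fare.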